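Cyclopropylamino to benzylamino at the assay limit

The source may report more compounds than this note shows. Statements on the series, on what has been measured and on what is new or still open speak of the compounds shown alone.

In a functional assay on L02 cells (Homo sapiens) for inhibition, read by Griess assay, with stated times of 1 h and 24 h (on this read-out lower numbers stand for stronger inhibition and higher numbers for weaker inhibition), compound 1 (`CCCc1nn(C)c2c(NCc3ccc(F)cc3)nc(/C=C/c3nc(C)c(C)nc3C)nc12`) gives > 1000000 nM as a limit of the assay and not a number. Compound 2 (`C(=C/c1ccco1)\c1nc(NC2CC2)c2sccc2n1`) gives > 1000000 nM in this assay and this too is a limit. Compound 2 thus stands at the limit of > 1000000 nM in this assay, at which 2 of the 2 values shown sit, and carries no number of its own.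

Compound 3 (`C(=C/c1ccco1)\c1nc(NCc2ccccc2)c2sccc2n1`) follows from compound 2 with benzyl in place of cyclopropyl on a nitrogen on an aromatic ring. Going by the values given here, no measured step gives a size for such a change. The estimated step of a number no higher from compound 2 to compound 3 (the limit leaves the size open) in this assay is expected to stay within the usual scatter, with no direction favoured. This expectation rests only on compound 2 at > 1000000 nM as a limit, so it is a weak one. Compound 3 is estimated at 1000000 nM with an expected range of 300000 nM to 3000000 nM and will most likely be reported as a limit again.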

Compound 3, half-maximal inhibitory concentration: > 1000000 nM
Compound 3 ended at the assay's limit (the forecaster's own chance of this, stated with the estimate: 80%); the middle value sits exactly at the limit.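

Going by these compounds alone, compound 2 and compound 3 both stand at a limit in this assay, so the change from cyclopropylamino to benzylamino gives no step that can be read. The compounds shown leave open how large the effect of any single change is, and whether any of them has a measurable inhibition in this assay, with every value at one mark: the limit of > 1000000 nM in this assay, at which 3 of the 3 values shown sit.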